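Naphthyl Swap on a Weakly Inhibiting Quinazoline Sulfonamide

This account rests on a few compounds, and the source may have more. Where it says the series, first, only, none or still open, it means among the compounds named here.

Compound 2 `COc1cc2nc(N3CCN(S(=O)(=O)c4cc(F)c(Cl)c(C(=O)O)c4)CC3)nc(N)c2cc1OC` gives 56000 nM in a functional assay on PC-3 cells (Homo sapiens) for inhibition; on this read-out lower numbers stand for stronger inhibition and higher numbers for weaker inhibition. Among the measured compounds shown here, its only neighbour, compound 1 `COc1cc2nc(N3CCN(S(=O)(=O)c4cccc([N+](=O)[O-])c4)CC3)nc(N)c2cc1OC`, gives 32000 nM in this assay, and the two sit within the scatter of each other: a 1.8-fold higher number from compound 1 to compound 2 (0.24 log units; within the scatter). That single step exchanges one aryl group on the sulfonyl sulfur for another and moves nothing beyond the scatter. Compound 3 `COc1cc2nc(N3CCN(S(=O)(=O)c4cccc5ccccc45)CC3)nc(N)c2cc1OC` makes a change of the same kind: naphthalen-1-yl in place of 3-carboxy-4-chloro-5-fluorophenyl on a sulfonyl sulfur. Because a 1.8-fold higher number from compound 1 to compound 2 (0.24 log units; within the scatter) stayed flat, the expected step is a 1.4-fold lower number from compound 2 to compound 3 (0.15 log units; within the scatter). Compound 3 is therefore estimated at 40000 nM, within a range from 10000 nM to 160000 nM.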

Compound 3, half-maximal inhibitory concentration: 14000 nM
Compound 3: the middle estimate sits 2.9-fold (0.46 log units) above what was measured; low and high end bracket the measured number.
By their numbers in this assay, from the lowest: compound 3; then compounds 1 and 2 (each within the scatter of the next).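

Unlike the earlier swap between two single-ring aryl groups, this change on the sulfonyl sulfur moves the number beyond the scatter in this assay. Naphthalen-1-yl in place of 3-carboxy-4-chloro-5-fluorophenyl gives a clear drop (a 4.0-fold lower number from compound 2 to compound 3 (0.60 log units; beyond the scatter)), and in place of 3-nitrophenyl a smaller one (a 2.3-fold lower number from compound 1 to compound 3 (0.36 log units; beyond the scatter)). Both steps are modest, but they show that the aryl group at this place can shift the number.

No supporting data explain the shift. As far as these compounds go, whether a cyclohexyl group or an amine on the naphthalene would move it further remains open.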